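Swapping a bromophenyl for a protected amine chain

This account rests on a few compounds, and the source may have more. Where it says the series, first, only, none or still open, it means among the compounds named here.

Compound 2 `O=C(Nc1ccc(NCc2ccc(Br)cc2)cc1Cl)c1cc(Cl)ccc1O` holds the higher of the two numbers measured in an ADME assay on A549 cells (Homo sapiens) for cytotoxicity, read by resazurin assay, with a stated time of 48 h; on this read-out higher numbers stand for lower toxicity in this test and lower numbers for higher toxicity in this test: compound 2 gives 40900 nM, whereas compound 1 `O=C(Nc1ccc(N(CC2CC2)CC2CC2)cc1Cl)c1cc(Cl)ccc1O` gives 12800 nM. Going by the values given here, the one measured step, a 3.2-fold higher number from compound 1 to compound 2 (0.50 log units; beyond the scatter), shows how far a change at the nitrogen on an aromatic ring has moved this read-out so far. Compound 3 `CC(C)(C)OC(=O)NCCNc1ccc(NC(=O)c2cc(Cl)ccc2O)c(Cl)c1` alters that same nitrogen in another way: ((tert-butoxycarbonyl)amino)methyl in place of 4-bromophenyl on a saturated chain carbon bound to a nitrogen on an aromatic ring. Among the compounds with values here, no measured step covers this exact exchange, so the only guidance is that the single step seen so far was modest. A step of similar or smaller size is therefore expected, with no clear direction, and the value of compound 3 in this assay is estimated at 45000 nM, within a range from 15000 nM to 120000 nM. The step of a 1.1-fold higher number from compound 2 to compound 3 (0.04 log units; within the scatter) is expected to stay close to the usual scatter.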

Compound 3, half-maximal cytotoxic concentration: 25000 nM
Compound 3: middle estimate off by 1.8-fold (0.26 log units), on the high side, within the range that was stated.
By their numbers in this assay, from the lowest: compounds 1, 3 and 2 (each within the scatter of the next, the first and the last beyond it).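

Replacing 4-bromophenyl with ((tert-butoxycarbonyl)amino)methyl gives a 1.6-fold lower number from compound 2 to compound 3 (0.21 log units; within the scatter) in this assay, so this read-out does not separate the two compounds. On a saturated chain carbon bound to a nitrogen on an aromatic ring, a six-membered aromatic ring of carbon only can therefore give way to a group with no ring, 1 hydrogen-bond donor and 2 hydrogen-bond acceptors, without a change beyond the scatter. Nothing available explains this result.

This single pair cannot show whether the same holds for other groups at this carbon, such as a free amine, a carboxylic acid or a longer chain. It also leaves open whether the tert-butoxycarbonyl part or the chain carrying it matters more for this read-out.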